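Carbamate series: cyclohexyl for isopropyl on the nitrogen

The source may report more compounds than this note shows. Statements on the series, on what has been measured and on what is new or still open speak of the compounds shown alone.

Of the compounds shown here, three share one core and have been measured in a functional assay on FM3A cells (Mus musculus) for inhibition; a lower number here means a stronger inhibitor, a higher number a weaker inhibitor. Compound 1 `CCCCNC(=O)OC/C=C(\C)C1=CC(=O)C(C)(C)O1` gives 7.7 ug/mL. Compound 2 `C/C(=C\COC(=O)NC(C)C)C1=CC(=O)C(C)(C)O1` gives 7.2 ug/mL. Compound 3 `C/C(=C\C=C\c1ccccc1)C1=CC(=O)C(C)(C)O1`, which carries no carbamate, gives 15 ug/mL. Among the compounds with values here, the only one-place step measured so far is a 1.1-fold lower number from compound 1 to compound 2 (0.03 log units; within the scatter), so the two carbamates sit within the scatter of each other. Compound 2 has the lowest number of the three; the gap to compound 1 is within the scatter, while the gap to compound 3 lies beyond it.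

Compound 4 `C/C(=C\COC(=O)NC1CCCCC1)C1=CC(=O)C(C)(C)O1` has not been measured yet. It differs from compound 2 in one place: cyclohexyl in place of isopropyl on an amide-type nitrogen. The step that bears on this change is a 1.1-fold lower number from compound 1 to compound 2 (0.03 log units; within the scatter), where a change of the group on the same nitrogen, butyl to isopropyl, left the number within the scatter. On that basis a group of a different size on the same nitrogen is expected to produce at most a small step in this assay, in no firm direction. Compound 4 is therefore expected to give about 7 ug/mL, with a range of 3.5 ug/mL to 14 ug/mL, which would mean a step of a 1.0-fold lower number from compound 2 to compound 4 (0.01 log units; within the scatter).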

Compound 4, half-maximal inhibitory concentration: 13 ug/mL
Estimate against measurement, compound 4: 1.9-fold (0.27 log units) below, and the stated range covers the measured number.
By their numbers in this assay, from the lowest: compounds 2, 1, 4 and 3 (each within the scatter of the next, the first and the last beyond it).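

Within the data shown here, with cyclohexyl on the nitrogen, the position now carries a ring for the first time, and in this assay the step is a 1.8-fold higher number from compound 2 to compound 4 (0.26 log units; within the scatter) and, against the straight chain, a 1.7-fold higher number from compound 1 to compound 4 (0.23 log units; within the scatter). Both steps are larger than the butyl to isopropyl step, yet each stays within the scatter, so straight-chain butyl, branched isopropyl and ring-bearing cyclohexyl are not separated at this position by the steps listed for compound 1, compound 2 and compound 4. Nothing on hand accounts for the size of these steps, and whether they reflect a real trend with the group on the nitrogen cannot be settled from these compounds.

Open, going by these compounds, is whether a phenyl or benzyl group on the same nitrogen, or a chain ending in a hydroxyl or an amine, would move the number beyond the scatter. Also open, on these data alone, is what a urea in place of the carbamate would do with the same cyclohexyl group.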